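Bromo for hydrogen on a phenyl ring, two series

The compounds below may be only part of what the source reports. "The series", "measured", "known", "first", "only" and "open" are said of these compounds alone.

Measured in a functional assay on MCF7 cells (Homo sapiens) for cytotoxicity, read by MTT assay, with a stated time of 72 h; a higher number here means a weaker inhibitor, a lower number a stronger inhibitor:
compound 1 `O=C(CSC(=S)N[C@H]1CCOC1=O)Nc1ccc(Br)cc1` gives 66500 nM
compound 2 `O=C(CSC(=S)N[C@H]1CCOC1=O)Nc1ccccc1` gives > 128000 nM, a limit of the assay and not a number
compound 3 `O=C(CCl)Nc1ccc(C(=O)/C=C/c2ccccc2)cc1` gives 2480 nM

Compound 1 differs from compound 2 by bromo in place of hydrogen on an aromatic carbon. The step is an at least 1.9-fold lower number from compound 2 to compound 1 (0.28 log units; that floor lies within the scatter); it rests on (the limit of > 128000 nM in this assay, at which 1 of the 3 values shown sits), so only a floor is known. How compound 3 differs from compound 2 is not broken down here; in this assay compound 3 stands lowest of the two numbers, well beyond the scatter from compound 1.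

Compound 4 `O=C(CCl)Nc1ccc(C(=O)/C=C/c2ccc(Br)cc2)cc1` is not yet measured. It differs from compound 3 by bromo in place of hydrogen on an aromatic carbon, the same change as between compound 2 and compound 1, at a place described in the same words. From compound 3 to compound 4 the expected step in this assay is a 1.5-fold lower number from compound 3 to compound 4 (0.16 log units; within the scatter), resting on the floor given by an at least 1.9-fold lower number from compound 2 to compound 1 (0.28 log units; that floor lies within the scatter). Compound 4 is therefore estimated at 1700 nM, with a likely range from 600 nM to 5000 nM.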

Compound 4, half-maximal inhibitory concentration: 4640 nM
Compound 4: the middle estimate sits 2.7-fold (0.44 log units) below what was measured, and the stated range covers the measured number.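

Bromo in place of hydrogen on the second core gives a 1.9-fold higher number from compound 3 to compound 4 (0.27 log units; within the scatter) in this assay, a step that does not separate the two compounds. Set beside the step on the first core, the change does not carry over as one fixed step from one core to the other: the same change on two cores in this assay, an at least 1.9-fold lower number (0.28 log units; that floor lies within the scatter) from compound 2 to compound 1 and a 1.9-fold higher number (0.27 log units; within the scatter) from compound 3 to compound 4, at least 3.6-fold (0.55 log units) apart, beyond the scatter of two such steps. Compound 2 stands at a limit and not a number, so the earlier step is only a floor, and with a single pair on each core no rule follows for any further core: the limit of > 128000 nM in this assay, at which 1 of the 4 values shown sits.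

Open, from the compounds shown here alone, is whether the gap between the two steps belongs to the cores or to bromo itself; a second group at the same place on both cores, such as chloro, methoxy or a carboxylic acid, would bear on that. Also open, going by these compounds, is how the first core behaves with its phenyl ring carrying an amine, where a measured number on both sides of the step would replace the floor.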